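Changing the amide of compound 2 into an ester

The source may hold more compounds than are shown below. What is called first, only, known or untested is meant among the compounds shown, and "the series" means these compounds.

For the measured compounds named here, compound 2 `CCOc1ccc(NC(=O)c2ccc(C(CC)(CC)c3ccc(OCC(O)C(C)(C)C)c(C)c3)n2CC)cc1` gives 630 nM in an assay on HL-60 cells for agonist activity at vitamin D3 receptor (Homo sapiens), read by microscopy, with a stated time of 96 h (a higher number here means that more compound is needed for the effect, a lower number that less compound is needed), the lower of the two numbers so far, while compound 1 `CCn1c(C(=O)N(C)CCC#N)ccc1C(CC)(CC)c1ccc(OCC(O)C(C)(C)C)c(C)c1` gives 1960 nM. Compound 3 `CCn1c(C(=O)OCc2ccc(F)cc2)ccc1C(CC)(CC)c1ccc(OCC(O)C(C)(C)C)c(C)c1` differs from compound 2 by (4-fluorobenzyl)oxy in place of (4-ethoxyphenyl)amino on a carbonyl carbon. Going by the values given here, the only measured step at this carbonyl carbon, a 3.1-fold lower number from compound 1 to compound 2 (0.49 log units; beyond the scatter), shows that swapping the group here can shift the number beyond the scatter. Among the compounds with values here, no measured step involves an ester, so the direction for compound 3 rests on little. A modest rise is expected for compound 3, namely a 1.7-fold higher number from compound 2 to compound 3 (0.24 log units; within the scatter). Compound 3 is therefore estimated at 1100 nM, within a range of 300 nM to 4000 nM.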

Compound 3, half-maximal effective concentration: > 50000 nM
Compound 3: a limit, no number (the forecaster's own chance of this, stated with the estimate: 5%); middle value at least 45-fold (1.65 log units) away from the limit.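

The two amides, compound 1 and compound 2, stay within a narrow span at this carbonyl carbon, a 3.1-fold lower number from compound 1 to compound 2 (0.49 log units; beyond the scatter), whereas the ester falls far outside it: an at least 79-fold higher number from compound 2 to compound 3 (1.89 log units; beyond the scatter), and an at least 25-fold higher number from compound 1 to compound 3 (1.40 log units; beyond the scatter). So this position tolerates some change among amides, but not this ester. In this assay, compound 3 gives only a limit, not a number: the limit of > 50000 nM in this assay, at which 1 of the 3 values shown sits.

The change swaps the linking atom and the aromatic group together, so the compounds shown cannot separate the two. A (4-fluorobenzyl)amino amide or a (4-ethoxyphenyl)oxy ester would tell them apart.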